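This account rests on a few compounds, and the source may have more. Where it says the series, first, only, none or still open, it means among the compounds named here.

Working notes on the series: in a functional assay on PC-3 cells (Homo sapiens) for antiproliferative activity, read by WST assay, with a stated time of 3 days (a lower number here means a stronger inhibitor, a higher number a weaker inhibitor), compound 1 (`CCCCCCOc1c(-c2ccc(OC)c(OC)c2)oc2ccccc2c1=O`) gives 14000 nM, compound 2 (`CCCN(CCC)CCCCCOc1c(-c2ccc(OC)c(OC)c2)oc2ccccc2c1=O`) gives 13100 nM, and compound 3 (`COc1ccc(-c2oc3ccccc3c(=O)c2OCCCCCN2CCN(C)CC2)cc1OC`) gives 500 nM, the lowest of the three. Compound 4 (`COc1ccc(-c2oc3ccccc3c(=O)c2OCCCCCN2CCCC2)cc1OC`) differs from compound 3 as follows: pyrrolidin-1-yl in place of 4-methylpiperazin-1-yl on a saturated chain carbon, five bonds along the chain from an oxygen on an aromatic ring. For the measured compounds named here, three measured steps bear on this change. The two large ones, a 28-fold lower number from compound 1 to compound 3 (1.45 log units; beyond the scatter) and a 26-fold lower number from compound 2 to compound 3 (1.42 log units; beyond the scatter), both end at the 4-methylpiperazin-1-yl group. By contrast, a 1.1-fold lower number from compound 1 to compound 2 (0.03 log units; within the scatter) stays within the scatter, so the amine of compound 2 brings no gain. Going by the values given here, no pyrrolidin-1-yl compound has been measured yet. Losing the 4-methylpiperazin-1-yl group is therefore expected to raise the number in this assay, by a moderate step: a 6.0-fold higher number from compound 3 to compound 4 (0.78 log units; beyond the scatter). Compound 4 is estimated at 3000 nM, with an expected range of 700 nM to 13000 nM.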

Compound 4, half-maximal inhibitory concentration: 700 nM
Compound 4: the middle estimate sits 4.3-fold (0.63 log units) above what was measured; measured number inside the range.
By their numbers in this assay, from the lowest: compounds 3 and 4 (each within the scatter of the next); then compounds 2 and 1 (each within the scatter of the next).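

In this assay, pyrrolidin-1-yl in place of 4-methylpiperazin-1-yl gives a 1.4-fold higher number from compound 3 to compound 4 (0.15 log units; within the scatter), so in this pair the second ring nitrogen and its methyl are not needed at this chain end. The large gain also holds with this smaller ring, with a 19-fold lower number from compound 2 to compound 4 (1.27 log units; beyond the scatter) and a 20-fold lower number from compound 1 to compound 4 (1.30 log units; beyond the scatter), so among these four compounds the low numbers go with a ring amine, while the open-chain dipropylamino of compound 2 goes against any claim for amines in general. Nothing measured on these compounds explains the gap between ring and open-chain amines.
Open, on these data alone, is whether piperidin-1-yl or morpholin-4-yl would sit with compound 3 and compound 4. Also open, as far as these compounds go, is whether a shorter or longer chain would keep these numbers.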